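Thiazole acetic acids at prostaglandin D2 receptor 2: compound 3

The compounds below may be only part of what the source reports. "The series", "measured", "known", "first", "only" and "open" are said of these compounds alone.

Compound 1 `Cc1nc(-c2ccc(Cl)cc2)c(CC(=O)O)s1` and compound 2 `N#Cc1ccc(-c2nc(C(c3ccc(F)cc3)c3ccc(F)cc3)sc2CC(=O)O)cc1` have been run in an in vitro functional assay on HEK285-7 cells for antagonist activity at prostaglandin D2 receptor 2 (Homo sapiens), read by BRET and beta-arrestin recruitment; a lower number here means a stronger inhibitor, a higher number a weaker inhibitor. Compound 1 gives 41000 nM in this assay, and compound 2 gives 1500 nM, the lower of the two numbers. Compound 3 `Nc1cc(-c2nc(C(c3ccc(F)cc3)c3ccc(F)cc3)sc2CC(=O)O)cc(F)n1` has not yet been measured; it differs from compound 2 in one place: 2-amino-6-fluoropyridin-4-yl in place of 4-cyanophenyl on an aromatic carbon. Among the compounds with values here, no measured pair isolates this change, so the step is expected to be small, either way, and likely within the scatter. Compound 3 is expected to give 1000 nM in this assay, within 300 nM to 5000 nM. The step of a 1.5-fold lower number from compound 2 to compound 3 (0.18 log units; within the scatter) is therefore an estimate, not a measurement.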

Compound 3, half-maximal inhibitory concentration: 1400 nM
The estimate for compound 3 lay 1.4-fold (0.15 log units) below the measured number; the range from low to high includes it.
By their numbers in this assay, from the lowest: compounds 3 and 2 (each within the scatter of the next); then compound 1.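

In this assay, within the data shown here, 2-amino-6-fluoropyridin-4-yl in place of 4-cyanophenyl gives a 1.1-fold lower number from compound 2 to compound 3 (0.03 log units; within the scatter) and is the first pair to isolate this position. On this aromatic carbon, next to the ring nitrogen, the nitrile-bearing carbon ring and the amino- and fluoro-substituted ring with 1 hetero atom cannot be told apart. No supporting data bear on why this is so.

From the compounds shown here alone, the separate contributions of the amino group and the fluorine remain open. A pyridin-4-yl carrying only one of them, or an unsubstituted phenyl, would address this.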